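Aryl exchange from compound 1 to compound 4

A few compounds are considered here, and "the series" means these few. Any claim that something is new, unique, unknown or untested is made for them only; others in the source may bear on it.

compound 1 `COc1cc(Nc2ncnc3c(NC(=O)Nc4cc(Cl)c(Cl)cc4Cl)cccc23)cc(OC)c1` gives 4890 nM
compound 2 `COc1cc(Nc2ncnc3c(NC(=O)Nc4ccc(C(F)(F)F)cc4[N+](=O)[O-])cccc23)cc(OC)c1` gives > 20000 nM as a limit
compound 3 `COc1cc(Nc2ncnc3c(NC(=O)Nc4cccc(C)c4C)cccc23)cc(OC)c1` gives 5910 nM
compound 4 `COc1cc(Nc2ncnc3c(NC(=O)Nc4cc(C)cc(C)c4)cccc23)cc(OC)c1` is not yet measured

In a functional assay on RT-112 cells (Homo sapiens) for antiproliferative activity, read by MTT assay, with a stated time of 72 h (a higher number here means a weaker inhibitor of growth, a lower number a stronger inhibitor of growth), compound 1 gives 4890 nM and sits within the scatter of compound 3 (5910 nM). Compound 2 gives > 20000 nM as a limit.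

The change to compound 4 is 3,5-dimethylphenyl in place of 2,4,5-trichlorophenyl on an amide-type nitrogen with 3,5-dimethylphenyl in place of 2,4,5-trichlorophenyl on an amide-type nitrogen. For the measured compounds named here, the one measured step that bears on it (a 1.2-fold higher number from compound 1 to compound 3 (0.08 log units; within the scatter)) puts 2,3-dimethylphenyl in place of 2,4,5-trichlorophenyl at that same nitrogen. No step beyond the scatter is therefore expected in this assay here. The expected step is small (a 1.1-fold higher number from compound 1 to compound 4 (0.05 log units; within the scatter)). Compound 4 is estimated at 5500 nM (2000 nM to 15000 nM).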

Compound 4, concentration for 50% growth inhibition: 10100 nM
Compound 4: the middle estimate sits 1.8-fold (0.26 log units) below what was measured; low and high end bracket the measured number.
By their numbers in this assay, from the lowest: compounds 1, 3 and 4 (each within the scatter of the next, the first and the last beyond it). At a limit, above all of these: compound 2.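

In this assay, for the compounds shown here, 3,5-dimethylphenyl at this amide-type nitrogen gives the first readable step beyond the scatter: a 2.1-fold higher number from compound 1 to compound 4 (0.32 log units; beyond the scatter). The two dimethylphenyl groups remain within the scatter of each other, with a 1.7-fold higher number from compound 3 to compound 4 (0.23 log units; within the scatter), so moving from 2,3-dimethylphenyl to 3,5-dimethylphenyl shows no separate effect here. Nothing measured here accounts for either step.

On these data alone, whether a carboxylic acid or an amine on this aryl ring would give a lower number than compound 1 remains open. Compound 2 gives only a limit, so steps to it cannot be read.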